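The source may report more compounds than this note shows. Statements on the series, on what has been measured and on what is new or still open speak of the compounds shown alone.

Measured compounds in an ADME assay on microsomes from liver (Mus musculus) for metabolic stability, read by LC-MS, using NADPH, with stated times of 10 min and 30 min; a lower number here means slower removal, a higher number faster removal of the compound:

Compound 1 `CCC(=O)N[C@@H]1CCCc2c1cncc2N1C(=O)c2ccc(Cl)cc2[C@@H]1C` – compound 1 gives < 20.2 mL/min/kg, which is a limit of the assay and not a number.
Compound 2 `CCC(=O)N[C@@H]1CCCc2c1cncc2N1C(=O)c2ccc(Cl)cc2[C@@H]1CC` – compound 2 gives < 20.2 mL/min/kg, again a limit of the assay.
Compound 3 `CC(=O)N[C@@H]1CCCc2c1cncc2N1Cc2cc(Cl)ccc2C1=O` – compound 3 gives < 20.2 mL/min/kg, also a limit of the assay.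

All three values sit at the same limit, as the limit of < 20.2 mL/min/kg in this assay, at which 3 of the 3 values shown sit, records. Compound 1 and compound 2 differ by methyl in place of hydrogen on a saturated chain carbon bound to a saturated ring carbon, and the step recorded for this pair in this assay is a step that the two limits leave unreadable from compound 1 to compound 2. Compound 3 carries a core that differs from that of compound 1 in more than one place, so the difference between the two cores is not broken down here.

The unmeasured compound 4 `CCC(=O)N[C@@H]1CCCc2c1cncc2N1Cc2cc(Cl)ccc2C1=O` is built from compound 3 by methyl in place of hydrogen on a saturated chain carbon bound to a carbonyl carbon. This is the same kind of change as that from compound 1 to compound 2, but around a different place: there the added methyl sits on a saturated chain carbon bound to a saturated ring carbon, here on a saturated chain carbon bound to a carbonyl carbon. Because compound 3 gives < 20.2 mL/min/kg and the related pair shows a step that the two limits leave unreadable from compound 1 to compound 2, the estimated step in this assay is a step that the limit leaves unreadable from compound 3 to compound 4. Compound 4 is therefore expected to give about 12 mL/min/kg in this assay, with an expected range from 5 mL/min/kg to 25 mL/min/kg.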

Compound 4, clearance: < 20.2 mL/min/kg
Compound 4: only a limit was reported; the forecaster's own chance of this, stated with the estimate: 80%; the middle value is on the limit's open side.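

In this assay compound 4 gives < 20.2 mL/min/kg, which is a limit of the assay and not a number. No new step can be read from compound 1, compound 2 or compound 3 to compound 4, because all four compounds share one limit: the limit of < 20.2 mL/min/kg in this assay, at which 4 of the 4 values shown sit.

The compounds shown leave open how the four actually compare in this assay.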